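Carbonyl substituents and cytotoxicity in one shared core

The source may hold more compounds than are shown below. What is called first, only, known or untested is meant among the compounds shown, and "the series" means these compounds.

Compound 1 `Cc1c(C(=O)c2ccc(Oc3ccccc3)cc2)oc2cc(-c3ccccc3)cc(O)c12` gives in a functional assay on WI-38 VA13 cells (Homo sapiens) for cytotoxicity (a lower number here means that less compound is needed, a higher number that more compound is needed for the effect), only the limit > 4 ug/mL.
Compound 2 `Cc1c(C(=O)c2ccc(F)c(F)c2)oc2cc(-c3ccccc3)cc(O)c12` gives in this assay 0.4 ug/mL.
Compound 3 `Cc1c(C(=O)CCc2ccccc2)oc2cc(-c3ccccc3)cc(O)c12` gives in this assay only the limit > 4 ug/mL.

Compound 3 thus stands at the limit, as does compound 1 (the limit of > 4 ug/mL in this assay, at which 2 of the 3 values shown sit). Among the measured compounds shown here, the only measured step bearing on the carbonyl substituent is an at least 10-fold higher number from compound 2 to compound 3 (1.00 log units; beyond the scatter). Compound 4 `COc1ccccc1C(=O)c1oc2cc(-c3ccccc3)cc(O)c2c1C` reverses that direction of change: 2-methoxyphenyl in place of phenethyl on a carbonyl carbon. An aryl group on the carbonyl carbon does not by itself give a number, as compound 1 shows, so the expected step of an at least 2.0-fold lower number from compound 3 to compound 4 (0.30 log units; that floor lies within the scatter) in this assay is a lowering of uncertain size. For compound 4 the estimate is 2 ug/mL, within 0.5 ug/mL to 8 ug/mL.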

Compound 4, half-maximal effective concentration: 0.09 ug/mL
Compound 4: the middle estimate sits 22-fold (1.35 log units) above what was measured; the whole stated range lies above it.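

Replacing phenethyl with 2-methoxyphenyl on the carbonyl carbon gives an at least 44-fold lower number from compound 3 to compound 4 (1.64 log units; beyond the scatter) in this assay. As far as these compounds go, the value of compound 3, > 4 ug/mL, is a limit of the assay, so the true size of that step remains unknown. Among the aryl groups at this position, the choice of substituents also matters, with a 4.4-fold lower number from compound 2 to compound 4 (0.65 log units; beyond the scatter).

From the compounds shown here alone, what the methoxy group itself contributes stays open. So does how a plain phenyl group or an amine-bearing chain on the carbonyl carbon would compare in this assay.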